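The compounds below may be only part of what the source reports. "The series", "measured", "known", "first", "only" and "open" are said of these compounds alone.

Within the data shown here, in a functional assay with Cavia porcellus as the target (a higher number here means a weaker inhibitor, a lower number a stronger inhibitor), only two compounds have been measured. Compound 1 `C=CC[N+](C)(C)c1ccc(O)cc1` reaches the limit of the assay in this assay, reported as > 3000 nM, a limit and not a number. Among the measured compounds shown here, compound 2 `COc1ccc(C(=O)COc2cccc([N+](C)(C)C)c2)cc1OC` is the only one with a measured value in this assay, where compound 2 gives 7080 nM; it therefore stands alone, set against (the limit of > 3000 nM in this assay, at which 1 of the 2 values shown sits).

Compound 3 `COc1ccc(C(=O)COc2cccc([N+](C)(C)Cc3ccccc3)c2)cc1OC` is not yet measured. It differs from compound 2 by phenyl in place of hydrogen on a saturated chain carbon bound to a nitrogen on an aromatic ring. For the measured compounds named here, no measured pair shows what such a change does in this assay, so no size or direction can be drawn from the numbers at hand. The expectation for compound 3 is that the step of a 1.4-fold lower number from compound 2 to compound 3 (0.15 log units; within the scatter) stays within the usual scatter. On this basis compound 3 is estimated to give 5000 nM in this assay, with a likely range from 1500 nM to 20000 nM.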

Compound 3, half-maximal inhibitory concentration: 1690 nM
Estimate against measurement, compound 3: 3.0-fold (0.47 log units) above; measured number inside the range.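

Phenyl in place of hydrogen on a saturated chain carbon bound to a nitrogen on an aromatic ring, which also reads as methyl to benzyl, gives in this assay a 4.2-fold lower number from compound 2 to compound 3 (0.62 log units; beyond the scatter). Among these compounds, no earlier pair spoke to this position, and this one shows that the number responds to a change there and that the larger benzyl group goes with stronger inhibition, not weaker. Nothing measured among these compounds bears on why the number falls.

The compounds shown do not tell whether the aromatic ring itself matters or only the added carbon atoms, which a cyclohexylmethyl group in place of benzyl could separate. Also open, on these data alone, is how a longer chain such as phenethyl, or a methoxy group or chlorine on the phenyl, would move the number.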